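The source may hold more compounds than are shown below. What is called first, only, known or untested is meant among the compounds shown, and "the series" means these compounds.

Measured so far in a functional assay on MOLT-4 cells (Homo sapiens) for inhibition, read by MTT assay, with a stated time of 72 h; a higher number here means a weaker inhibitor, a lower number a stronger inhibitor:
compound 1 `COc1cc(NC(C)CCCNC(=O)Nc2ccc(F)cc2)c2ncccc2c1` gives 24000 nM;
compound 2 `COc1cc(NC(C)CCCNC(=O)NNC(=O)Nc2ccc(O)cc2)c2ncccc2c1` gives 104000 nM;
compound 3 `COc1cc(NC(C)CCCNC(=O)Nc2cccc(Cl)c2)c2ncccc2c1` gives 21000 nM.

Among these three numbers compound 1 stands second highest. Its nearest neighbour is compound 3, reached by a 1.1-fold lower number from compound 1 to compound 3 (0.06 log units; within the scatter), a step that stays within the usual scatter of this assay. Its furthest neighbour is compound 2, reached by a 4.3-fold higher number from compound 1 to compound 2 (0.64 log units; beyond the scatter), a step clearly beyond the scatter.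

The compound not yet measured is compound 4 `COc1cc(NC(C)CCCNC(=O)Nc2ccc(Br)cc2)c2ncccc2c1`. It differs from compound 1 only in one spot: bromo in place of fluoro on an aromatic carbon.

Of the measured steps, the one that bears most directly on this change is the swap of one halogen-bearing phenyl for another, a 1.1-fold lower number from compound 1 to compound 3 (0.06 log units; within the scatter), which left the number essentially where it was. The step of a 4.3-fold higher number from compound 1 to compound 2 (0.64 log units; beyond the scatter) replaced the whole phenyl ring with a larger group and so speaks less to a simple halogen exchange. On this basis the expected outcome is a 1.1-fold lower number from compound 1 to compound 4 (0.04 log units; within the scatter), that is, no step beyond the scatter in either direction. For compound 4 the estimated value in this assay is 22000 nM, with a likely range from 11000 nM to 45000 nM.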

Compound 4, half-maximal inhibitory concentration: 25000 nM
The estimate for compound 4 lay 1.1-fold (0.06 log units) below the measured number; measured number inside the range.
By their numbers in this assay, from the lowest: compounds 3, 1 and 4 (each within the scatter of the next); then compound 2.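

Compound 1 and compound 3 differed in both the halogen and its place on the ring, whereas compound 4 keeps the place of compound 1 and changes only the halogen. In this assay, that exchange of fluoro for bromo on an aromatic carbon, para to a large group, shows no effect beyond the scatter (a 1.0-fold higher number from compound 1 to compound 4 (0.02 log units; within the scatter)), and 4-bromophenyl likewise cannot be told apart from 3-chlorophenyl (a 1.2-fold higher number from compound 3 to compound 4 (0.08 log units; within the scatter)). The three halogen-bearing compounds therefore form one group in this small set, with compound 2 standing apart (a 4.2-fold lower number from compound 2 to compound 4 (0.62 log units; beyond the scatter)), and no measurement shown here explains this result.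

The compounds shown leave open whether a non-halogen group on the same aromatic carbon, such as an amine, a carboxylic acid or a methoxy group, would move the number beyond the scatter. They also leave open whether a longer chain between the shared core and the urea would change the number, since that chain is the same in all four compounds.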